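Methyl for chloro on the fused benzene ring

This account rests on a few compounds, and the source may have more. Where it says the series, first, only, none or still open, it means among the compounds named here.

Measured compounds in a functional assay on the whole organism with Rattus norvegicus as the target, at a dose of 20 mg/kg by the oral route; on this read-out lower numbers stand for less inhibition and higher numbers for more inhibition at the one dose given (going by the name of the read-out):
compound 1, `Cc1cccc2c1CC/C2=C\C(=O)NC1CC1`, 15%
compound 2, `NC(=O)/C=C1\CCc2c(F)cccc21`, 40%
compound 3, `NC(=O)/C=C1\CCc2c(Cl)cccc21`, 35%

Compound 3 stands second highest of the three numbers. Its nearest neighbour is compound 2, whose value sits within the scatter of it; the furthest is compound 1, which lies beyond the scatter on the low side. For the measured compounds named here, the only single-point step among the measured compounds, a number 5 percentage points lower from compound 2 to compound 3 (within the scatter), is within the scatter.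

Compound 4, `Cc1cccc2c1CC/C2=C\C(N)=O`, is not yet measured in this assay. It differs from compound 3 as follows: methyl in place of chloro on an aromatic carbon. Going by the values given here, compound 1 also carries the methyl, but it differs from compound 4 at the amide as well, so only the two values, compound 1 at 15% and compound 4 unknown, can be set side by side, with no step read off.

The bearing step, the halogen swap from compound 2 to compound 3, was within the scatter. The step to compound 4 is therefore expected to be small, a number 3 percentage points lower from compound 3 to compound 4 (within the scatter), with no clear direction. The expected value for compound 4 is 32%, within a range from 15% to 50%.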

Compound 4, a percentage reported as inhibition, in the whole organism at one dose (the size of the read-out at that dose, not a potency): 15%
Beside the measured number, compound 4's estimate is 17 percentage points above it; low and high end bracket the measured number.
By their numbers in this assay, from the lowest: compounds 1 and 4 (each within the scatter of the next); then compounds 3 and 2 (each within the scatter of the next).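

For the compounds shown here, on the aromatic carbon of the fused system, the halogens had given only a step within the scatter, and methyl is the first change here to go beyond it: chloro to methyl gives (a number 20 percentage points lower from compound 3 to compound 4 (beyond the scatter)), and fluoro to methyl gives (a number 25 percentage points lower from compound 2 to compound 4 (beyond the scatter)). In this assay the position therefore distinguishes methyl from both halogens, at this one oral dose. With methyl in place, the amide nitrogen adds no visible difference (no change at the digits printed from compound 1 to compound 4 (within the scatter)), so hydrogen and cyclopropyl cannot be told apart in this methyl pair.

Still open, from the compounds shown here alone, is how methoxy, trifluoromethyl or an unsubstituted aromatic carbon would read at this position, and whether cyclopropyl on the amide nitrogen would read the same alongside fluoro or chloro. Nothing at hand bears on what separates methyl from the halogens in this read-out.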